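The source may hold more compounds than are shown below. What is called first, only, known or untested is meant among the compounds shown, and "the series" means these compounds.

Compound 3 `C=CC(=O)Nc1cc(Nc2ncc(Cl)c(Nc3ccccc3S(=O)(=O)C(C)C)n2)c(OC)cc1N1CCN(C(C)C)CC1` in a functional assay on NCI-H1975 cells (Homo sapiens) for inhibition, read by CellTiter-Glo, with a stated time of 72 h (on this read-out lower numbers stand for stronger inhibition of growth and higher numbers for weaker inhibition of growth), gives 25 nM, the highest of the three numbers gathered here, although its gaps to compound 1 `C=CC(=O)Nc1cc(Nc2ncc(Cl)c(Nc3ccccc3S(=O)(=O)C(C)C)n2)c(OC)cc1N1CCC(N2CCN(C)CC2)CC1` with 23 nM and to compound 2 `C=CC(=O)Nc1cc(Nc2ncc(Cl)c(Nc3ccccc3S(=O)(=O)C(C)C)n2)c(OC)cc1N1CCCN(C)CC1` with 15 nM both lie within the scatter, so no order among them can be claimed. Compound 4 `C=CC(=O)Nc1cc(Nc2ncc(Cl)c(Nc3ccccc3S(=O)(=O)C(C)C)n2)c(OC)cc1N1CCCCC1` differs from compound 3 in one place: piperidin-1-yl in place of 4-isopropylpiperazin-1-yl on an aromatic carbon. Going by the values given here, the only measured step touching this position, a 1.7-fold higher number from compound 2 to compound 3 (0.22 log units; within the scatter), exchanged one ring with two hetero atoms for another and changed little. Among the compounds with values here, no measured compound carries a ring with a single hetero atom at this place, so that step offers only weak guidance. A modest weakening is expected, with wide uncertainty: compound 4 is estimated at 60 nM, between 15 nM and 250 nM, meaning a 2.4-fold higher number from compound 3 to compound 4 (0.38 log units; beyond the scatter).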

Compound 4, concentration for 50% growth inhibition: 240 nM
Estimate against measurement, compound 4: 4.0-fold (0.60 log units) below; the range from low to high includes it.
By their numbers in this assay, from the lowest: compounds 2, 1 and 3 (each within the scatter of the next); then compound 4.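

In this assay this position proves sensitive: plain piperidin-1-yl costs far more than the earlier ring exchange did (a 9.6-fold higher number from compound 3 to compound 4 (0.98 log units; beyond the scatter); a 16-fold higher number from compound 2 to compound 4 (1.20 log units; beyond the scatter)). Compound 1 also has a piperidine ring here, yet removing its 4-methylpiperazin-1-yl (a 10-fold higher number from compound 1 to compound 4 (1.02 log units; beyond the scatter)) causes a similar loss, so among these compounds the ring alone does not set the number, and the further nitrogen-bearing group matters. Nothing available explains this loss. Going by these compounds, whether morpholin-4-yl, with oxygen where the piperazine ring has its second nitrogen, would keep the number low remains open.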